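Methyl on the Outer Phenyl of a Thiosemicarbazide Series

A few compounds are considered here, and "the series" means these few. Any claim that something is new, unique, unknown or untested is made for them only; others in the source may bear on it.

Potency was followed in a functional assay on U-373MG ATCC cells (Homo sapiens) for inhibition, read by colorimetric assay and MTT assay, with a stated time of 72 h; a lower number here means a stronger inhibitor, a higher number a weaker inhibitor. Compound 1, `O=C(NNC(=S)Nc1csc(-c2ccccc2)c1)c1ccc(O)cc1`, returns only a limit of the assay in this assay, > 100000 nM, so no number is known for it. Compound 2, `Cc1ccc(-c2cc(NC(=S)NNC(=O)c3ccc(O)cc3)cs2)cc1`, gives 64000 nM in this assay. The change between them is methyl in place of hydrogen on an aromatic carbon, and it made an at least 1.5-fold lower number from compound 1 to compound 2 (0.19 log units; that floor lies within the scatter), a floor set because compound 1 sits at the limit of > 100000 nM in this assay, at which 1 of the 3 values shown sits. Compound 3, `COc1ccc(C(=O)NNC(=S)Nc2csc(-c3ccccc3)c2)cc1OC`, gives 59000 nM in this assay; the difference between the cores of compound 1 and compound 3 is not broken down here. Compound 3 and compound 2 lie within the scatter of each other.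

Compound 4, `COc1ccc(C(=O)NNC(=S)Nc2csc(-c3ccc(C)cc3)c2)cc1OC`, has not been measured. It differs from compound 3 by methyl in place of hydrogen on an aromatic carbon, the same change, at the same kind of place, that separates compound 1 from compound 2. Starting from compound 3, a step of about a 1.3-fold lower number from compound 3 to compound 4 (0.12 log units; within the scatter) is expected, resting on an at least 1.5-fold lower number from compound 1 to compound 2 (0.19 log units; that floor lies within the scatter), which only sets a floor. For compound 4 the estimate is 45000 nM, most likely between 20000 nM and 100000 nM.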

Compound 4, half-maximal inhibitory concentration: 47000 nM
Compound 4: the middle estimate sits 1.0-fold (0.02 log units) below what was measured; measured number inside the range.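

Going by these compounds alone, on this second core, going from phenyl to 4-methylphenyl gives a 1.3-fold lower number from compound 3 to compound 4 (0.10 log units; within the scatter) in this assay, so the methyl produces no step that can be told apart from the ordinary spread of repeated measurements. Nothing here shows that the change carries from one core to the other with a fixed size, and nothing shows that it fails to carry: the same change on two cores in this assay, an at least 1.5-fold lower number (0.19 log units; that floor lies within the scatter) from compound 1 to compound 2 and a 1.3-fold lower number (0.10 log units; within the scatter) from compound 3 to compound 4; the limit leaves it open whether they differ

Compound 1 gives > 100000 nM, which is a limit of the assay and not a number.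

The compounds shown hold only hydrogen or methyl at this place on the outer phenyl, so it stays open what an amine, a carboxylic acid or a longer chain such as ethyl would do there. Also open, going by these compounds, is whether any group at this place can produce a step beyond the scatter on either core.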